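A few compounds are considered here, and "the series" means these few. Any claim that something is new, unique, unknown or untested is made for them only; others in the source may bear on it.

Measured so far:
- compound 1 `C[C@@H](NC(=O)Nc1ccc(C(C)(C)C)cc1)c1ccccc1`: 88% in an ADME assay on the whole organism with Oryza sativa as the target, tested at 1 uM; a higher number here means a weaker effect of the compound at the concentration tested, a lower number a stronger effect
- compound 2 `C[C@H](NC(=O)Nc1ccc(C(C)(C)C)cc1)c1ccccc1`: 88%
- compound 3 `CC(=O)c1ccc(NC(=O)N[C@@H](C)c2ccccc2)cc1`: 99%

Compound 1 stands level with compound 2, and the two share the lowest number of the three; compound 3 is furthest away. The step from compound 1 to compound 2 is no change at the digits printed from compound 1 to compound 2 (within the scatter), which fits (the fact that compounds 1 and 2 differ only in the configuration as drawn). The step from compound 2 to compound 3 is a number 11 percentage points higher from compound 2 to compound 3 (beyond the scatter), so exchanging the group on that aromatic carbon moved the number by a modest amount.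

Compound 4 `C[C@@H](NC(=O)Nc1ccc(Br)cc1)c1ccccc1` has not yet been measured. It differs from compound 1 in this way: bromo in place of tert-butyl on an aromatic carbon

Among the measured compounds shown here, only one measured step bears on this change, the exchange of the same tert-butyl for acetyl from compound 2 to compound 3, which gave a modest rise. For the measured compounds named here, no measured step introduces bromo, so the direction for compound 4 rests on that single comparison. A small rise or no change beyond the scatter is the expectation, giving an estimated step of a number 4 percentage points higher from compound 1 to compound 4 (within the scatter). For compound 4 the expected value is 92%, in a range from 80% to 100%.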

Compound 4, a percentage reported as activity, at one concentration (the size of the read-out at that concentration, not a potency): 95%
Compound 4: middle estimate off by 3 percentage points, on the low side, and the stated range covers the measured number.
By their numbers in this assay, from the lowest: compounds 1, 2, 4 and 3 (each within the scatter of the next, the first and the last beyond it).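

In this assay, exchanging the tert-butyl, with its four carbons, for a single bromine atom on this aromatic carbon gives a number 7 percentage points higher from compound 1 to compound 4 (within the scatter). A group of one heavy atom and a group of four heavy atoms therefore cannot be told apart here, which the earlier exchange of tert-butyl for acetyl, a number 11 percentage points higher from compound 2 to compound 3 (beyond the scatter), did not show, since that step lies beyond the scatter. The only explanatory fact available concerns configuration and has no bearing on the exchange of tert-butyl for bromo.

What the compounds shown leave open is whether an amine, a carboxylic acid or a plain hydrogen on this aromatic carbon would give a step beyond the scatter, and whether bromo behaves differently from tert-butyl at all once repeat measurements narrow the scatter. Also open, from the compounds shown here alone, is whether the bromo compound drawn with the opposite configuration would match compound 4, as compound 2 matches compound 1 with tert-butyl in place.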